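The compounds below may be only part of what the source reports. "The series", "measured", "known", "first", "only" and "open" are said of these compounds alone.

Measured compounds:
- compound 1 `CCN(CC)Cc1cc2c(N)nc(-c3ccco3)nc2s1` gives 2130 nM
- compound 2 `Nc1nc(-c2ccco2)nc2sc(CNC3CC3)cc12` gives 1890 nM
- compound 3 `Nc1nc(-c2ccco2)nc2sc(CNC3CCCCC3)cc12` gives 2480 nM

In an assay on CHO-K1 cells for antagonist activity at adenosine receptor A1 (Homo sapiens), read by a beta-galactosidase reporter, with stated times of 15 min and 6 h (on this read-out higher numbers stand for weaker inhibition and lower numbers for stronger inhibition), compound 3 carries the highest of the three numbers, yet the steps of a 1.2-fold higher number from compound 1 to compound 3 (0.07 log units; within the scatter) and a 1.3-fold higher number from compound 2 to compound 3 (0.12 log units; within the scatter) both lie within the scatter, so the three compounds cannot be told apart. Compound 4 `Nc1nc(-c2ccco2)nc2sc(CN3CCCC3)cc12` differs from compound 3 by pyrrolidin-1-yl in place of cyclohexylamino on a saturated chain carbon bound to an aromatic carbon. Among the compounds with values here, the steps that bear on this change are a 1.1-fold lower number from compound 1 to compound 2 (0.05 log units; within the scatter), a 1.2-fold higher number from compound 1 to compound 3 (0.07 log units; within the scatter) and a 1.3-fold higher number from compound 2 to compound 3 (0.12 log units; within the scatter), each swapping the group on that same chain carbon and each within the scatter. A further swap at the same place is therefore expected to give a step of a 1.1-fold lower number from compound 3 to compound 4 (0.05 log units; within the scatter) that stays within the scatter. Compound 4 is estimated at 2200 nM, in a range from 1100 nM to 4400 nM.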

Compound 4, inhibition constant: 6430 nM
Compound 4: the middle estimate sits 2.9-fold (0.47 log units) below what was measured, outside the stated range (above it).
By their numbers in this assay, from the lowest: compounds 2, 1 and 3 (each within the scatter of the next); then compound 4.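

In this assay the group on this chain carbon does matter: pyrrolidin-1-yl gives a 2.6-fold higher number from compound 3 to compound 4 (0.41 log units; beyond the scatter) and a 3.4-fold higher number from compound 2 to compound 4 (0.53 log units; beyond the scatter) and a 3.0-fold higher number from compound 1 to compound 4 (0.48 log units; beyond the scatter) as modest steps, although the three earlier amines could not be told apart. Of these four groups, only pyrrolidin-1-yl joins the chain carbon through a ring nitrogen. No measurement shown explains why this group stands apart.

As far as these compounds go, whether the larger piperidin-1-yl ring would behave the same way remains open. So does the effect of morpholin-4-yl, which adds a ring oxygen.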